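A few compounds are considered here, and "the series" means these few. Any claim that something is new, unique, unknown or untested is made for them only; others in the source may bear on it.

Measured so far:
compound 1 `COc1cc(/C=C/C(=O)c2ccccc2F)cc(OC)c1OC`: 134 nM
compound 2 `COc1cc(OC)c(OC)cc1/C=C/C(=O)c1ccccc1F`: 55.3 nM
compound 3 `COc1cc(/C=C/C(=O)c2ccccc2F)cc(OC)c1`: 20.9 nM

In a functional assay on HCT-15 cells (Homo sapiens) for cytotoxicity, read by MTT assay, with a stated time of 72 h (a higher number here means a weaker inhibitor, a lower number a stronger inhibitor), compound 3 gives the lowest number of the three and compound 1 the highest. Compound 1 and compound 2 share the same atoms joined differently; the difference between the two cores is not broken down here. From compound 1 to compound 3 the change is hydrogen in place of methoxy on an aromatic carbon, and the step is a 6.4-fold lower number from compound 1 to compound 3 (0.81 log units; beyond the scatter).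

Compound 4 `COc1ccc(OC)c(/C=C/C(=O)c2ccccc2F)c1` awaits measurement in this assay. It differs from compound 2 by hydrogen in place of methoxy on an aromatic carbon. This is the same kind of change, not the same: the carbon losing the methoxy is here ortho to a methoxy group and meta to a methoxy group, rather than ortho to two methoxy groups. The expectation rests on a 6.4-fold lower number from compound 1 to compound 3 (0.81 log units; beyond the scatter) and on compound 2 at 55.3 nM. The expected step is a 2.0-fold lower number from compound 2 to compound 4 (0.30 log units; within the scatter), smaller than the earlier one. Compound 4 is estimated at 28 nM, between 10 nM and 80 nM.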

Compound 4, half-maximal inhibitory concentration: 61.1 nM
Compound 4: middle estimate off by 2.2-fold (0.34 log units), on the low side; measured number inside the range.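

In this assay, hydrogen in place of methoxy on an aromatic carbon does not carry over as one fixed step from core to core: the same change on two cores in this assay, a 6.4-fold lower number (0.81 log units; beyond the scatter) from compound 1 to compound 3 and a 1.1-fold higher number (0.04 log units; within the scatter) from compound 2 to compound 4, 7.1-fold (0.85 log units) apart, beyond the scatter of two such steps. The new step, a 1.1-fold higher number from compound 2 to compound 4 (0.04 log units; within the scatter), shows no readable change on this core, so the clear shift seen on the other core cannot be assumed here. For the compounds shown here, only two pairs stand behind this, and the methoxy lost sits in a different place in each, so the data do not separate an effect of the core from one of that place, nor predict the step on a further core.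

Open, going by these compounds, is how a hydroxyl, an amine or an ethoxy group would read on the carbon that loses the methoxy in compound 4. On these data alone, the part played by the fluorine also stays open, with the fluorinated ring the same in all four compounds.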